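This account rests on a few compounds, and the source may have more. Where it says the series, first, only, none or still open, it means among the compounds named here.

Compound 2, `NC1=NC2(CCOCC2)N(OCCCOc2cc(Cl)c(Cl)cc2Cl)C(N)=N1`, is one of three compounds with a measured value in a functional assay on HL-60 cells (Homo sapiens) for antiproliferative activity, read by MTT assay, with a stated time of 72 h; on this read-out lower numbers stand for stronger inhibition and higher numbers for weaker inhibition. In that assay compound 2 gives 2360 nM, the highest of the three numbers. Compound 3, `NC1=NC2(CCSCC2)N(OCCCOc2ccc(Cl)cc2)C(N)=N1`, is the nearest and gives 430 nM. Compound 1, `NC1=NC2(CCSCC2)N(OCCCOc2cccc(Cl)c2)C(N)=N1`, is the furthest and gives 260 nM. The core of compound 1 and compound 3 is not the core of compound 2, so the gap between compound 2 and those two cannot be assigned to the aryl group alone.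

Compound 4, `NC1=NC2(CCOCC2)N(OCCCOc2ccccc2Br)C(N)=N1`, has the core of compound 2 and differs from it in a single place: 2-bromophenyl in place of 2,4,5-trichlorophenyl on an oxygen on a saturated carbon

Among the measured compounds shown here, the only measured single step, a 1.7-fold higher number from compound 1 to compound 3 (0.22 log units; within the scatter), concerns a change of one chlorine position on the other core and shows no movement beyond the scatter. For the measured compounds named here, no measured step touches the exchange of a three-chlorine aryl group for a one-bromine aryl group, nor any change on the core of compound 2. The two mono-halogenated compounds, compound 1 and compound 3, both sit far below compound 2, which weighs towards a lower number for compound 4, but with wide uncertainty. For compound 4 the estimated step is a 2.6-fold lower number from compound 2 to compound 4 (0.42 log units; beyond the scatter). The estimated value for compound 4 is therefore 900 nM, within a range from 300 nM to 2700 nM.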

Compound 4, half-maximal inhibitory concentration: 610 nM
The estimate for compound 4 lay 1.5-fold (0.17 log units) above the measured number; the measured number falls inside the stated range.
By their numbers in this assay, from the lowest: compounds 1, 3 and 4 (each within the scatter of the next, the first and the last beyond it); then compound 2.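

In this assay, among the compounds shown here, the step on the core of compound 2 is the first measured change of the aryl group on that core: a 3.9-fold lower number from compound 2 to compound 4 (0.59 log units; beyond the scatter), beyond the scatter, with 2-bromophenyl in place of 2,4,5-trichlorophenyl on an oxygen on a saturated carbon. For the compounds shown here, the only earlier single step, a 1.7-fold higher number from compound 1 to compound 3 (0.22 log units; within the scatter), moved one chlorine on the other core and stayed within the scatter, so this is the first sign that a change of aryl group at this place can shift the number by more than the scatter. Nothing available offers a reason for this shift.

On these data alone, three chlorines leave and one bromine enters in a single step, so it remains open whether the shift follows the number of halogens, the kind of halogen or their places on the ring. As far as these compounds go, it also remains open how 2-chlorophenyl or an unsubstituted phenyl would read on the core of compound 2, and what an amine on the aryl ring or a longer chain in place of the present one would do.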